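Alkoxy chain extension on the shared core, next step

The source may report more compounds than this note shows. Statements on the series, on what has been measured and on what is new or still open speak of the compounds shown alone.

Compound 1 `COc1nc2c(c(=O)n(C)c(=O)n2C)n1CCCC(=O)Nc1ccc(C(C)(C)C)cc1` in an assay on isolated protein for inhibition of high affinity 3',5'-cyclic-AMP phosphodiesterase 7A (Homo sapiens), read by cAMP accumulation, with a stated time of 10 min (a higher number here means a weaker inhibitor, a lower number a stronger inhibitor), gives 19800 nM; compound 2 `CCOc1nc2c(c(=O)n(C)c(=O)n2C)n1CCCC(=O)Nc1ccc(C(C)(C)C)cc1` gives 54300 nM, the highest of the two numbers shown. Going by the values given here, the one step on record, a 2.7-fold higher number from compound 1 to compound 2 (0.44 log units; beyond the scatter), came from methyl in place of hydrogen on a saturated chain carbon bound to an oxygen on an aromatic ring. Compound 3 `CCCOc1nc2c(c(=O)n(C)c(=O)n2C)n1CCCC(=O)Nc1ccc(C(C)(C)C)cc1` carries the same difference cut one bond further out: methyl in place of hydrogen on a saturated chain carbon, two bonds along the chain from an oxygen on an aromatic ring. Among the compounds with values here, only that step bears on it, so a further rise in this assay of similar size is expected, a 1.7-fold higher number from compound 2 to compound 3 (0.24 log units; within the scatter). Compound 3 is estimated at 95000 nM, range 40000 nM to 250000 nM.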

Compound 3, half-maximal inhibitory concentration: 7760 nM
Estimate against measurement, compound 3: 12-fold (1.09 log units) above; the measured number lies below the stated range.
By their numbers in this assay, from the lowest: compound 3; then compound 1; then compound 2.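

In this assay the added methyl reverses direction on a saturated chain carbon, two bonds along the chain from an oxygen on an aromatic ring: ethoxy to propoxy gives a fall (a 7.0-fold lower number from compound 2 to compound 3 (0.84 log units; beyond the scatter)), where the earlier step gave a rise. The propoxy group also ends lower than the start of the series (a 2.6-fold lower number from compound 1 to compound 3 (0.41 log units; beyond the scatter)), so across these three compounds the number does not follow chain length in one direction. Nothing at hand explains this turn.

As far as these compounds go, whether a butoxy or longer chain continues the fall stays open. So does the effect of a branched isopropoxy group or a terminal amine at this position.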